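Swapping an aryl for a thiazole on the sulfonyl bridge

The source may hold more compounds than are shown below. What is called first, only, known or untested is meant among the compounds shown, and "the series" means these compounds.

This account follows compound 1, whose structure is `CC(O)(C(=O)Nc1ccc(S(=O)(=O)c2ccccc2F)cc1)C(F)(F)F`, and asks what a single replacement on it may do. For the measured compounds named here, in a functional assay (Cavia porcellus) with sulfonylurea receptors; K-ATP channels (Homo sapiens) as the target (on this read-out lower numbers stand for stronger inhibition and higher numbers for weaker inhibition), compound 1 gives 1300 nM, the lowest of the two numbers so far. Going by the values given here, the only other compound measured, compound 2 with structure `CC(O)(C(=O)Nc1ccc(C(=O)c2ccccc2)cc1F)C(F)(F)F`, gives 11000 nM in this assay; the two values differ by an amount beyond the usual scatter, so compound 1 stands as the stronger of the pair on this read-out. Among the compounds with values here, no pair differing in one place has been measured, so no step size from the data itself is available.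

Compound 3, with structure `CC(O)(C(=O)Nc1ccc(S(=O)(=O)c2nccs2)cc1)C(F)(F)F`, has not been measured. It differs from compound 1 as follows: 1,3-thiazol-2-yl in place of 2-fluorophenyl on a sulfonyl sulfur. Because compound 1 gives 1300 nM, the expected step from compound 1 to compound 3 in this assay is a 1.5-fold higher number from compound 1 to compound 3 (0.19 log units; within the scatter), a small weakening at most, possibly none beyond the scatter. Compound 3 is therefore estimated at 2000 nM, with a range from 600 nM to 7000 nM.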

Compound 3, half-maximal inhibitory concentration: 1400 nM
Beside the measured number, compound 3's estimate is 1.4-fold (0.15 log units) above it; the measured number falls inside the stated range.
By their numbers in this assay, from the lowest: compounds 1 and 3 (each within the scatter of the next); then compound 2.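

In this assay, the first step read at this place on a sulfonyl sulfur is small (a 1.1-fold higher number from compound 1 to compound 3 (0.03 log units; within the scatter)), which puts compound 1 and compound 3 within the scatter of each other. The read-out therefore does not separate 1,3-thiazol-2-yl from 2-fluorophenyl here, even though the entering group is a five-membered aromatic ring with 2 hetero atoms and 2 hydrogen-bond acceptors, and the leaving group is a six-membered aromatic ring of carbon only with no hydrogen-bond acceptors. Nothing available explains why the two compounds read alike.

On these data alone, this single pair cannot show how far that tolerance extends, so the effect on the same sulfonyl sulfur of a small methyl group, a pyridine ring, or a chain ending in an amine or a carboxylic acid remains open. Also open, as far as these compounds go, is what the fluorine of the 2-fluorophenyl contributes, a question that a plain phenyl on the same sulfur could answer directly.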